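Chromone amine chain variation: dimethylamino to pyrrolidinyl

This account rests on a few compounds, and the source may have more. Where it says the series, first, only, none or still open, it means among the compounds named here.

Measured in a functional assay on HepG2 cells (Homo sapiens) for cytotoxicity, read by MTT assay, with a stated time of 72 h; on this read-out lower numbers stand for stronger inhibition and higher numbers for weaker inhibition:
compound 1 `COc1ccccc1-c1cc(=O)c2c(O)cc(OCCCCN3CCN(C)CC3)c(OC)c2o1` gives 2330 nM
compound 2 `COc1c(OCCCCN2CCN(C)CC2)cc(O)c2c(=O)cc(-c3ccc(F)cc3)oc12` gives 2810 nM
compound 3 `CN(C)CCCOc1c(OCc2ccccc2)cc(O)c2c(=O)cc(-c3ccccc3)oc12` gives 4950 nM

The only single-point step among these, a 1.2-fold higher number from compound 1 to compound 2 (0.08 log units; within the scatter), changes the aryl group and lies within the scatter. Compound 3 carries the highest number of the three; its gap to compound 1 lies beyond the scatter, while its gap to compound 2 lies within it.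

Compound 4 `O=c1cc(-c2ccccc2)oc2c(OCCCN3CCCC3)c(OCc3ccccc3)cc(O)c12` differs from compound 3 by pyrrolidin-1-yl in place of dimethylamino on a saturated chain carbon, three bonds along the chain from an oxygen on an aromatic ring. Within the data shown here, no measured step touches the amine end of the chain, so the data give no direction for this change. For compound 4 the expectation is therefore a step of a 1.0-fold lower number from compound 3 to compound 4 (0.00 log units; within the scatter), none beyond the scatter, with this assay estimated at 4900 nM and a range of 2400 nM to 10000 nM.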

Compound 4, half-maximal inhibitory concentration: 2660 nM
Estimate against measurement, compound 4: 1.8-fold (0.27 log units) above, and the stated range covers the measured number.
By their numbers in this assay, from the lowest: compounds 1, 4, 2 and 3 (each within the scatter of the next, the first and the last beyond it).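

Among these compounds, this is the first reading at the amine end of the chain: in this assay, pyrrolidin-1-yl in place of dimethylamino on the 3-carbon-named propyl chain's end gives a 1.9-fold lower number from compound 3 to compound 4 (0.27 log units; within the scatter). In this pair, the five-membered ring at the chain end is therefore not separable from dimethylamino. No mechanistic data bear on this step.

On these data alone, whether a piperidine or a morpholine at the chain end, or a longer chain, would separate from these two amines stays open. So does whether the same exchange reads alike with other aryl groups on the shared core.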